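The source may hold more compounds than are shown below. What is called first, only, known or untested is meant among the compounds shown, and "the series" means these compounds.

In a functional assay on HCT-116 cells (Homo sapiens) for antiproliferative activity, read by CellTiter-Glo, with a stated time of 72 h (on this read-out higher numbers stand for weaker inhibition and lower numbers for stronger inhibition), compound 1 `O=C(NO)c1cccc(/C=C/c2ccnc(-c3cc(F)ccc3O)c2)c1` gives 3890 nM, compound 2 `O=C(NO)c1cccc(/C=C/c2ccnc(-c3ccccc3O)c2)c1` gives 3360 nM and compound 3 `O=C(NO)c1ccc(/C=C/c2ccnc(-c3cc(F)ccc3O)c2)cc1` gives 2040 nM. These three values all lie within the usual scatter of one another, so the numbers give compound 3 no firm rank against the other two.

Compound 4 `O=C(NO)c1ccc(/C=C/c2ccnc(-c3ccccc3O)c2)cc1` differs from compound 3 in a single place: hydrogen in place of fluoro on an aromatic carbon. This is hydrogen in place of fluoro on an aromatic carbon, so 5-fluoro-2-hydroxyphenyl becomes 2-hydroxyphenyl.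

The same exchange has been measured once, in a close relative with a different shared core: a 1.2-fold lower number from compound 1 to compound 2 (0.06 log units; within the scatter). Among the compounds with values here, that single step stays within the scatter, and it is the only direct guide available. No change beyond the scatter is therefore expected here, and the estimated step is a 1.1-fold lower number from compound 3 to compound 4 (0.05 log units; within the scatter). For compound 4 the estimated value is 1800 nM, with an expected range of 950 nM to 3500 nM.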

Compound 4, half-maximal inhibitory concentration: 1450 nM
Compound 4: the middle estimate sits 1.2-fold (0.09 log units) above what was measured; the range from low to high includes it.
By their numbers in this assay, from the lowest: compounds 4, 3, 2 and 1 (each within the scatter of the next, the first and the last beyond it).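

In this assay, the exchange of fluoro for hydrogen now gives a 1.4-fold lower number from compound 3 to compound 4 (0.15 log units; within the scatter) on a second core, where before it had been read on the core of compound 1 alone. On both cores the exchange stays within the scatter, and the two steps agree with each other: the same change on two cores in this assay, a 1.2-fold lower number (0.06 log units; within the scatter) from compound 1 to compound 2 and a 1.4-fold lower number (0.15 log units; within the scatter) from compound 3 to compound 4, 1.2-fold (0.08 log units) apart, within the scatter of two such steps. In these two pairs, then, the fluoro group at this place, para to a hydroxy group, can give way to hydrogen with no difference that this read-out can separate from the scatter.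

Going by these compounds, what a chloro, a methoxy or an amine at the same place would do remains open. So does the effect on this read-out of exchanging the hydroxy group itself, for instance for a methoxy group.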